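The source may hold more compounds than are shown below. What is called first, only, known or untested is meant among the compounds shown, and "the series" means these compounds.

Measured compounds:

Compound 1, `COc1cccc(Cc2cnc(CCc3ccc(-c4ccccc4C(=O)O)cc3)[nH]2)c1`: in an in vitro functional assay on cells for agonist activity at Bombesin receptor subtype-3 (Homo sapiens), read by luminescence and calcium flux (a lower number here means that less compound is needed, a higher number that more compound is needed for the effect), compound 1 gives 4120 nM.
Compound 2, `Cc1cccc(Cc2cnc(CCc3ccc(-c4ccccc4C(=O)O)cc3)[nH]2)c1`: in this assay compound 2 gives 4310 nM.

On the numbers shown, compound 2 and compound 1 sit within the scatter of each other: the change of a 1.0-fold higher number from compound 1 to compound 2 (0.02 log units; within the scatter) is small, and the two cannot be told apart. The step to compound 3, `CC(C)(C)Cc1cnc(CCc2ccc(-c3ccccc3C(=O)O)cc2)[nH]1`, is tert-butyl in place of 3-methylphenyl on a saturated chain carbon bound to an aromatic carbon. Going by the values given here, no measured step bears on this change directly; the one step in hand, a 1.0-fold higher number from compound 1 to compound 2 (0.02 log units; within the scatter), exchanges only a substituent on the aromatic ring that now leaves, and it was within the scatter. The present change removes that ring altogether, so the measured data give no guide to its size or direction. For compound 3 a value of 8000 nM is therefore estimated, within a broad range from 2000 nM to 30000 nM, meaning an expected step of a 1.9-fold higher number from compound 2 to compound 3 (0.27 log units; within the scatter) that is itself uncertain.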

Compound 3, half-maximal effective concentration: 106 nM
Beside the measured number, compound 3's estimate is 75-fold (1.88 log units) above it, outside the stated range (below it).
By their numbers in this assay, from the lowest: compound 3; then compounds 1 and 2 (each within the scatter of the next).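

In this assay the earlier pair differed only in a substituent on the aromatic ring and could not be told apart, but this position responds strongly when that ring leaves altogether. Tert-butyl in place of 3-methylphenyl brings a large change (a 41-fold lower number from compound 2 to compound 3 (1.61 log units; beyond the scatter)), and tert-butyl in place of 3-methoxyphenyl brings one of similar size (a 39-fold lower number from compound 1 to compound 3 (1.59 log units; beyond the scatter)), so at this saturated chain carbon the aromatic ring is not needed for the effect, and far less compound is needed without it. Nothing available accounts for the size of this change.

A cyclohexyl or an n-butyl group on this carbon would bear on whether the change follows the loss of the aromatic ring or the tert-butyl group itself. Going by these compounds, whether a smaller group such as isopropyl would serve as well remains open.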